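A short-lived compound and its 3,4-dimethoxyphenyl relative

The source may report more compounds than this note shows. Statements on the series, on what has been measured and on what is new or still open speak of the compounds shown alone.

- compound 1 `Cc1cc(C)c(-c2nc(CN3CCC(C(=O)NCCCN4C[C@H](C)C[C@H](C)C4)CC3)c(C)o2)c(C)c1`: > 0.5 h
- compound 2 `Cc1oc(-c2ccc(Cl)c(Cl)c2)nc1CN1CCC(C(=O)NCCCN2C[C@H](C)C[C@H](C)C2)CC1`: > 0.5 h
- compound 3 `COc1cccc(Cl)c1-c1nc(CN2CCC(C(=O)NCCCN3C[C@H](C)C[C@H](C)C3)CC2)c(C)o1`: 0.055 h

All three values come from an ADME assay on microsomes from liver (Rattus norvegicus) for metabolic stability, read by LC-MS, using NADPH, at 37 degrees C; on this read-out lower numbers stand for a shorter-lived compound and higher numbers for a longer-lived compound. The entry for compound 1 is a limit and not a number. The entry for compound 2 is also a limit. Within the data shown here, compound 3 therefore holds the only true number, 0.055 h.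

The next compound is compound 4 `COc1ccc(-c2nc(CN3CCC(C(=O)NCCCN4C[C@H](C)C[C@H](C)C4)CC3)c(C)o2)cc1OC`, which has 3,4-dimethoxyphenyl in place of 2-chloro-6-methoxyphenyl on an aromatic carbon.

Among the measured compounds shown here, two measured steps bear on this change: an at least 9.0-fold lower number from compound 2 to compound 3 (0.95 log units; beyond the scatter) and an at least 9.0-fold lower number from compound 1 to compound 3 (0.95 log units; beyond the scatter). Both lie beyond the scatter. The first is the closer guide, since compound 2 carries 3,4-dichlorophenyl, a group with a similar name pattern to the incoming one. For the measured compounds named here, no measured compound carries the incoming group itself, so only part of that distance is expected to be recovered.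

The expected change is a 2.7-fold higher number from compound 3 to compound 4 (0.44 log units; beyond the scatter). Compound 4 is estimated at 0.15 h, with an expected range from 0.05 h to 0.5 h.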

Compound 4, half-life: > 0.5 h
Compound 4: a limit, no number; the forecaster's own chance of this, stated with the estimate: 20%; middle value at least 3.3-fold (0.52 log units) from the limit.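

The entry of compound 4 in this assay is > 0.5 h, which is a limit and not a number. Even so, the change gives an at least 9.0-fold higher number from compound 3 to compound 4 (0.95 log units; beyond the scatter), so a methoxy group on the phenyl ring is not enough for a short half-life, as 3,4-dimethoxyphenyl shows. The steps among compound 1, compound 2 and compound 4 cannot be read, so these three cannot be ranked, and compound 3 stands apart from them: the limit of > 0.5 h in this assay, at which 3 of the 4 values shown sit.

It remains open which part of 2-chloro-6-methoxyphenyl goes with the short half-life, as neither 2-chlorophenyl nor 2-methoxyphenyl appears among these compounds. Also open, on these data alone, is how a phenyl ring carrying an amine or a carboxylic acid would behave in this place.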